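Acid dissociation across three substituents on the shared core

The compounds below may be only part of what the source reports. "The series", "measured", "known", "first", "only" and "open" are said of these compounds alone.

Of the compounds shown here, three have been measured in a physicochemical assay for acid dissociation. Compound 1 `COc1ccc(F)cc1CNCCCNc1ccnc2cc(-c3ccccc3)ccc12` gives 9.47. Compound 2 `COc1ccc(F)cc1CNCCCNc1ccnc2cc(Oc3ccc(F)cc3)ccc12` gives 9.28, and the step of a number 0.19 log units lower from compound 1 to compound 2 (within the scatter) stays within the scatter. Compound 3 `COc1ccc(-c2ccc3c(NCCCNCc4cc(F)ccc4OC)ccnc3c2)cc1` gives 9.47, with no change at the digits printed from compound 1 to compound 3 (within the scatter) and a number 0.19 log units higher from compound 2 to compound 3 (within the scatter), both within the scatter. Compound 3 therefore stands level with compound 1, and compound 2 differs from it by no more than the usual scatter.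

Compound 4 `COc1ccc(F)cc1CNCCCNc1ccnc2cc(CC3CCCCC3)ccc12` is not yet measured. It differs from compound 3 by cyclohexylmethyl in place of 4-methoxyphenyl on an aromatic carbon. All three measured steps concern exchanges at this same aromatic carbon, and none of them reached beyond the scatter, so the change to cyclohexylmethyl is expected to behave in the same way. The step of a number 0.02 log units lower from compound 3 to compound 4 (within the scatter) is accordingly estimated to be no larger than the scatter. For compound 4 the expected value in this assay is 9.45, with a range from 9.15 to 9.75.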

Compound 4, acid dissociation constant: 9.47
Compound 4: middle estimate off by 0.02 log units, on the low side, and the stated range covers the measured number.
By their numbers in this assay, from the lowest: compounds 2, 1, 3 and 4 (each within the scatter of the next).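

In this assay, the exchange of an aromatic ring for a non-aromatic one at this aromatic carbon gives no change at the digits printed from compound 3 to compound 4 (within the scatter), and the comparison with phenyl gives no change at the digits printed from compound 1 to compound 4 (within the scatter). The comparison with the oxygen-linked 4-fluorophenoxy gives a number 0.19 log units higher from compound 2 to compound 4 (within the scatter), so a cyclohexylmethyl group, with its non-aromatic ring and a heavy-atom count close to that of 4-methoxyphenyl, extends the run of steps at this position that stay within the scatter. No supporting information bears on this result.

Every group shown at this carbon carries a six-membered ring of carbon only, so it remains open whether an amine, a carboxylic acid or a short open alkyl chain there would also stay within the scatter. The compounds also leave open whether changes elsewhere, such as a longer chain between the two nitrogens, would move the number.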